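Compound 1 to compound 3: the naphthalen-1-yl swap

The compounds below may be only part of what the source reports. "The series", "measured", "known", "first", "only" and "open" are said of these compounds alone.

Measured in a functional assay on HT-29 cells (Homo sapiens) for inhibition, read by MTT assay, with a stated time of 48 h; on this read-out higher numbers stand for weaker inhibition and lower numbers for stronger inhibition
- Compound 1 `COc1cc(-c2cc(-c3cccc([N+](=O)[O-])c3)nc(-c3ccccc3)n2)cc(OC)c1OC` gives > 25000 nM (a limit, no number)
- Compound 2 `COc1ccc(-c2cc(-c3cc(OC)c(OC)c(OC)c3)nc(-c3ccccc3)n2)c(OC)c1` gives > 25000 nM (a limit, no number)

Compound 1 stands only at a limit (> 25000 nM). Compound 2 also stands only at a limit (> 25000 nM). Nothing in the series yet rises off this ceiling (the limit of > 25000 nM in this assay, at which 2 of the 2 values shown sit).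

Compound 3 `COc1cc(-c2cc(-c3cccc4ccccc34)nc(-c3ccccc3)n2)cc(OC)c1OC` carries naphthalen-1-yl in place of 3-nitrophenyl on an aromatic carbon. Among the compounds with values here, one measured step bears on this change at the same place (a step that the two limits leave unreadable from compound 1 to compound 2), and it offers no size to carry over. A further limit in this assay is therefore the likeliest outcome. The expected step (an at least 1.2-fold lower number from compound 1 to compound 3 (0.09 log units; that floor lies within the scatter)) is small and, if it can be read at all, points toward stronger inhibition. For compound 3 the estimated value is 20000 nM, with an expected range from 5000 nM to 50000 nM.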

Compound 3, half-maximal inhibitory concentration: 4730 nM
For compound 3 the middle estimate is 4.2-fold (0.63 log units) above the measured one, and the stated range ends above it.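

In this assay, within the data shown here, the series comes off its ceiling for the first time, and it does so through a change at this single position on the shared core: naphthalen-1-yl in place of 3-nitrophenyl gives an at least 5.2-fold lower number from compound 1 to compound 3 (0.72 log units; beyond the scatter). The same group in place of 2,4-dimethoxyphenyl gives an at least 5.2-fold lower number from compound 2 to compound 3 (0.72 log units; beyond the scatter), so two different one-ring groups both fall short of it at this place. Each step is only a floor, and the step between compound 1 and compound 2 cannot be read: the limit of > 25000 nM in this assay, at which 2 of the 3 values shown sit.

Among these compounds, with only one two-ring group at this position, it stays open whether the second aromatic ring alone carries the step or whether its point of attachment matters, which naphthalen-2-yl would test. Also open, from the compounds shown here alone, is how a non-aromatic group such as morpholine would fare at this place.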